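Swapping amino for nitro: expected Vero cell tolerance

The compounds below may be only part of what the source reports. "The series", "measured", "known", "first", "only" and "open" are said of these compounds alone.

Three thiosemicarbazone-type compounds have been tested in an ADME assay on Vero cells (Chlorocebus sabaeus) for cytotoxicity, read by MTT assay, with a stated time of 72 h; a lower number here means that less compound is tolerated, a higher number that more compound is tolerated. Compound 1 `C/C(=N/NC(=S)N(Cc1ccccc1)Cc1ccccc1)c1ccc(N)cc1` gives 161000 nM, the lowest of the two full numbers reported in this assay. Compound 3 `C=CCN(CC=C)C(=S)N/N=C(/C)c1ccc(F)cc1` gives 214000 nM, which lies within the usual scatter of compound 1. For compound 2 `O=[N+]([O-])c1ccccc1/C=N\NC(=S)N(Cc1ccccc1)Cc1ccccc1` only a limit of the assay is reported, < 155000 nM; one of the three results sits at the limit of < 155000 nM in this assay, at which 1 of the 3 values shown sits.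

Compound 4 `C/C(=N/NC(=S)N(Cc1ccccc1)Cc1ccccc1)c1ccc([N+](=O)[O-])cc1` differs from compound 1 by one change: nitro in place of amino on an aromatic carbon. Among the measured compounds shown here, no measured pair shows this same change, so the step is expected to stay small, likely within the scatter, with a slight lean toward less compound being tolerated. The expected step from compound 1 to compound 4 is a 1.2-fold lower number from compound 1 to compound 4 (0.06 log units; within the scatter). Compound 4 is therefore estimated at 140000 nM, in a range from 60000 nM to 300000 nM.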

Compound 4, half-maximal cytotoxic concentration: < 150000 nM
Compound 4: no number, only a limit (the forecaster's own chance of this, stated with the estimate: 30%); the middle value lies beyond the limit too.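

For compound 4, this assay gives no number, only a limit: the limit of < 150000 nM in this assay, at which 1 of the 4 values shown sits.

Nitro in place of amino on this aromatic carbon, para to a large group, is the first one-place change that can be read here, and it gives an at least 1.0-fold lower number from compound 1 to compound 4 (0.03 log units; that floor lies within the scatter). On these data alone, that floor means the change may be slight or much larger, and the true size stays unknown.

As far as these compounds go, how far the real value of compound 4 lies past its limit remains open. So does whether a carboxylic acid or a methoxy group at this position would give a full number.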